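A few compounds are considered here, and "the series" means these few. Any claim that something is new, unique, unknown or untested is made for them only; others in the source may bear on it.

Within the data shown here, compound 2 `COc1ccc(CCCOC(=O)N(c2ccccc2)C2CN3CCC2CC3)cc1` is one of two compounds measured in an assay on CHO cells for displacement of a labelled ligand from muscarinic acetylcholine receptor M5 (Homo sapiens), read by scintillation counting, with a stated time of 2 h; a lower number here means a stronger inhibitor, a higher number a weaker inhibitor. In this assay compound 2 gives 640 nM, the higher of the two numbers; compound 1 `O=C(OCCc1ccc(Cl)c(Cl)c1)N(c1ccccc1)C1CN2CCC1CC2` gives 80 nM. Among the measured compounds shown here, the one recorded step, an 8.0-fold higher number from compound 1 to compound 2 (0.90 log units; beyond the scatter), is modest. Compound 3 `COc1ccc(CCOC(=O)N(c2ccccc2)C2CN3CCC2CC3)cc1OC` has not been measured. It differs from compound 2 in one place: 3,4-dimethoxyphenyl in place of 4-methoxybenzyl on a saturated chain carbon, two bonds along the chain from an oxygen next to a carbonyl group. This change partly reverses the earlier step, since it again places a phenyl ring carrying two groups, here 3,4-dimethoxyphenyl rather than 3,4-dichlorophenyl, on the saturated chain carbon two bonds along the chain from an oxygen next to a carbonyl group. Because an 8.0-fold higher number from compound 1 to compound 2 (0.90 log units; beyond the scatter) was modest and upward, a downward step of similar or smaller size is expected. For compound 3 the expected step is a 2.6-fold lower number from compound 2 to compound 3 (0.41 log units; beyond the scatter). Compound 3 is therefore estimated at 250 nM, within a range from 80 nM to 800 nM.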

Compound 3, inhibition constant: 3490 nM
Beside the measured number, compound 3's estimate is 14-fold (1.14 log units) below it; the whole stated range lies below it.
By their numbers in this assay, from the lowest: compound 1; then compound 2; then compound 3.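

In this assay, 3,4-dimethoxyphenyl did not bring the number back toward that of compound 1: the change gave a 5.5-fold higher number from compound 2 to compound 3 (0.74 log units; beyond the scatter) and so moved further up, not down. Set against 3,4-dichlorophenyl at the same place, the group gave a 44-fold higher number from compound 1 to compound 3 (1.64 log units; beyond the scatter) and the weakest result of the three, so a phenyl ring carrying two groups does not by itself give a low number here; what those two groups are matters. The data offer no explanation for this difference.

The step to compound 3 alters both the ring and the group's length at once, so a 4-methoxyphenyl group would be needed to tell those two changes apart. From the compounds shown here alone, how a longer chain, or a pyridine ring in this place, would read remains open.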